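The source may report more compounds than this note shows. Statements on the series, on what has been measured and on what is new or still open speak of the compounds shown alone.

In a functional assay on MCF7 cells (Homo sapiens) for inhibition, with a stated time of 96 h (on this read-out higher numbers stand for weaker inhibition and lower numbers for stronger inhibition), compound 3 (`COc1cc(C(=O)c2cn(-c3ccc(C)cc3)cc2-c2nccs2)cc(OC)c1OC`) gives 14 nM as its number, within the scatter of compound 2 (`COc1cc(C(=O)c2cn(-c3ccc(C)cc3)cc2-c2ccco2)cc(OC)c1OC`) at 22 nM and clearly under compound 1 (`COc1cc(C(=O)c2cn(-c3cccc(C)c3)cc2-c2ncco2)cc(OC)c1OC`) at 75 nM in the same read-out. Compound 4 (`COc1cc(C(=O)c2cn(-c3ccc(C)cc3)cc2-c2ncco2)cc(OC)c1OC`) differs from compound 3 in one place (1,3-oxazol-2-yl in place of 1,3-thiazol-2-yl on an aromatic carbon) on an aromatic carbon. Within the data shown here, the only measured step at this place is a 1.6-fold lower number from compound 2 to compound 3 (0.20 log units; within the scatter) and it stays within the scatter. Compound 1 also carries the 1,3-oxazol-2-yl group, but with a different methylphenyl group, so it offers only a loose guide. In this assay no step beyond the scatter is therefore expected, with perhaps a slight move to a higher number. The expected step is a 1.8-fold higher number from compound 3 to compound 4 (0.25 log units; within the scatter) and stays within the scatter. For compound 4 the estimated value is 25 nM with an expected range from 9 nM to 70 nM in this estimate.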

Compound 4, half-maximal inhibitory concentration: 42 nM
Beside the measured number, compound 4's estimate is 1.7-fold (0.23 log units) below it, and the stated range covers the measured number.
By their numbers in this assay, from the lowest: compounds 3, 2, 4 and 1 (each within the scatter of the next, the first and the last beyond it).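

Among these compounds, at this position, 1,3-oxazol-2-yl in place of 1,3-thiazol-2-yl gives the first step beyond the scatter in this assay, with a 3.0-fold higher number from compound 3 to compound 4 (0.48 log units; beyond the scatter), while the change from furan-2-yl gives a 1.9-fold higher number from compound 2 to compound 4 (0.28 log units; within the scatter). Among the compounds shown here, on the aromatic nitrogen, 4-methylphenyl in place of 3-methylphenyl gives a 1.8-fold lower number from compound 1 to compound 4 (0.25 log units; within the scatter), a first direct reading of that change. Nothing measured here accounts for the difference between the two rings. The compounds shown leave open how an amine or a carboxylic acid would read at this position. They also leave open whether the 1,3-thiazol-2-yl result would hold with 3-methylphenyl on the nitrogen.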